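The source may hold more compounds than are shown below. What is called first, only, known or untested is meant among the compounds shown, and "the series" means these compounds.

For the measured compounds named here, compound 3 `Cc1ccc(OCC(=O)N2CCN(c3ccc(C(F)(F)F)cc3[C@@H](N)CC(C)C)CC2)cc1` stands at the weak end of the three numbers so far: in an assay on HEK293 cells for displacement of a labelled ligand from Melanocortin receptor 4 (Homo sapiens) (on this read-out higher numbers stand for weaker inhibition and lower numbers for stronger inhibition), compound 3 gives 4400 nM. Compound 1 `Cc1ccc(CC(C)C(=O)N2CCN(c3ccc(C(F)(F)F)cc3[C@@H](N)CC(C)C)CC2)cc1C` gives 240 nM and compound 2 `COc1ccc(CC(C)C(=O)N2CCN(c3ccc(C(F)(F)F)cc3[C@@H](N)CC(C)C)CC2)cc1` gives 120 nM; between them lies a 2.0-fold lower number from compound 1 to compound 2 (0.30 log units; within the scatter), a step within the scatter. Compound 3 sits apart from both beyond the scatter: an 18-fold higher number from compound 1 to compound 3 (1.26 log units; beyond the scatter) and a 37-fold higher number from compound 2 to compound 3 (1.56 log units; beyond the scatter), both large, both accompanying the move to (4-methylphenoxy)methyl on the carbonyl carbon.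

Compound 4 `Cc1ccc(OCC(=O)N2CCN(c3ccc(C(F)(F)F)cc3[C@@H](N)CC(C)C)CC2)c(C)c1` keeps that group and adds (methyl in place of hydrogen on an aromatic carbon). Going by the values given here, no measured step isolates such a change: the step from compound 1 to compound 2 swaps the whole aryl group on a saturated chain carbon, two bonds along the chain from a carbonyl carbon, and stays within the scatter, while the two steps into compound 3 alter chain and aryl substitution together. The single added methyl is therefore expected to give a step no larger than the scatter in this assay, a 1.3-fold lower number from compound 3 to compound 4 (0.10 log units; within the scatter). Compound 4 is estimated at 3500 nM, with a range from 1200 nM to 10000 nM.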

Compound 4, inhibition constant: 4000 nM
Compound 4: the middle estimate sits 1.1-fold (0.06 log units) below what was measured; the range from low to high includes it.
By their numbers in this assay, from the lowest: compounds 2 and 1 (each within the scatter of the next); then compounds 4 and 3 (each within the scatter of the next).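

In this assay, methyl in place of hydrogen on an aromatic carbon, ortho to a large group and meta to a methyl group, stays within the scatter (a 1.1-fold lower number from compound 3 to compound 4 (0.04 log units; within the scatter)), so at this place the 2,4-dimethylphenoxy and 4-methylphenoxy groups cannot be told apart. The added methyl leaves the large gaps to the other two compounds in place (a 33-fold higher number from compound 2 to compound 4 (1.52 log units; beyond the scatter); a 17-fold higher number from compound 1 to compound 4 (1.22 log units; beyond the scatter)), and the (2,4-dimethylphenoxy)methyl group stays on the weak side of both. Nothing available gives a reason for these steps.

On these data alone, whether a methoxy group or a chlorine atom at this same place would also stay within the scatter remains open. The compounds shown also do not separate the ether oxygen of the (4-methylphenoxy)methyl group from the branched chain of compounds 1 and 2 as the source of the gap.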